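Urea Substituent Swap on a Shared Quinazoline-Free Core

This account rests on a few compounds, and the source may have more. Where it says the series, first, only, none or still open, it means among the compounds named here.

Measured so far:
- compound 1 `O=C(Nc1cc2c(Nc3ccc(F)c(Cl)c3)ncnc2cc1O[C@H]1CCOC1)N1CC(O)C1`: 1930 nM
- compound 2 `O=C(Nc1cc2c(Nc3ccc(F)c(Cl)c3)ncnc2cc1O[C@H]1CCOC1)N1CCC(N2CCCC2)CC1`: 317 nM

In a functional assay on A-431 cells (Homo sapiens) for antiproliferative activity, read by sulforhodamine B assay, with a stated time of 72 h (on this read-out higher numbers stand for weaker inhibition and lower numbers for stronger inhibition), compound 2 gives 317 nM, the lower of the two numbers, with compound 1 at 1930 nM. Among the compounds with values here, the only measured step, a 6.1-fold lower number from compound 1 to compound 2 (0.78 log units; beyond the scatter), shows that the group on the urea carbonyl carbon can move the read-out by a modest amount. Compound 3 `COC(=O)/C=C/CNC(=O)Nc1cc2c(Nc3ccc(F)c(Cl)c3)ncnc2cc1O[C@H]1CCOC1` carries the change ((3-(methoxycarbonyl)prop-2-en-1-yl)amino in place of 4-(pyrrolidin-1-yl)piperidin-1-yl on a carbonyl carbon). Within the data shown here, no measured pair covers this particular exchange, so the step from compound 1 to compound 2 is only an indirect guide: it shows the size such a replacement can reach, not its direction here. The best expectation is that compound 3 loses part of the gain seen in compound 2 and lands nearer compound 1, with an estimated 3.8-fold higher number from compound 2 to compound 3 (0.58 log units; beyond the scatter). The estimate for compound 3 in this assay is 1200 nM, within a range of 400 nM to 4000 nM.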

Compound 3, half-maximal inhibitory concentration: 1410 nM
Estimate against measurement, compound 3: 1.2-fold (0.07 log units) below; low and high end bracket the measured number.
By their numbers in this assay, from the lowest: compound 2; then compounds 3 and 1 (each within the scatter of the next).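

In this assay, putting the open-chain (3-(methoxycarbonyl)prop-2-en-1-yl)amino group in place of the 4-(pyrrolidin-1-yl)piperidin-1-yl group gives a 4.4-fold higher number from compound 2 to compound 3 (0.65 log units; beyond the scatter), so the lower number of compound 2 does not carry over to this replacement. Exchanging the 3-hydroxyazetidin-1-yl group for the same chain gives a 1.4-fold lower number from compound 1 to compound 3 (0.14 log units; within the scatter), so a group with a ring and a group with no ring cannot be told apart in this pair, and among these three groups only the 4-(pyrrolidin-1-yl)piperidin-1-yl group stands apart. Nothing available here offers an explanation for this pattern.

Going by these compounds, it remains open whether a plain piperidin-1-yl group, without the pyrrolidine ring, would keep the lower number of compound 2. How a carboxylic acid in place of the methyl ester of compound 3 would read is also unknown.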